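Compound 1 to compound 4: an ester replaces the amide

The compounds below may be only part of what the source reports. "The series", "measured", "known", "first", "only" and "open" are said of these compounds alone.

Compound 1 `CCn1c(C(=O)NCC(OC)OC)ccc1C(CC)(CC)c1ccc(OCC(O)C(C)(C)C)c(C)c1` is the most potent of the compounds measured in an assay on HL-60 cells for agonist activity at vitamin D3 receptor (Homo sapiens), read by microscopy, with a stated time of 96 h; on this read-out lower numbers stand for an effect already at smaller amounts and higher numbers for an effect only at larger amounts of compound: compound 1 gives 150 nM, a lower number than that of its nearest neighbour by a margin beyond the scatter. Compound 3 `CCOC(=O)c1ccc(OC(=O)c2ccc(C(CC)(CC)c3ccc(OCC(=O)C(C)(C)C)c(C)c3)n2CC)cc1` gives 45600 nM. Compound 2 `CCn1c(C(=O)Nc2cccc(C(F)(F)F)c2)ccc1C(CC)(CC)c1ccc(OCC(=O)C(C)(C)C)c(C)c1` reaches only the limit of the assay, > 50000 nM, so that for compound 2 no number is known (the limit of > 50000 nM in this assay, at which 1 of the 3 values shown sits). For the measured compounds named here, the one measured step, an at least 1.0-fold lower number from compound 2 to compound 3 (0.04 log units; that floor lies within the scatter), exchanges one carbonyl substituent for another and stays within the scatter, though both compounds differ from compound 1 in more than one place. Compound 4 `CCn1c(C(=O)OCc2ccc(F)cc2)ccc1C(CC)(CC)c1ccc(OCC(O)C(C)(C)C)c(C)c1` is separated from compound 1 by (4-fluorobenzyl)oxy in place of (2,2-dimethoxyethyl)amino on a carbonyl carbon. Going by the values given here, no measured step bears directly on this change, since compounds 2 and 3 carry a further difference; what they show is that aromatic groups on that carbonyl carbon went together with weak activity. Compound 4 is therefore expected to lose some potency, with a step of a 4.0-fold higher number from compound 1 to compound 4 (0.60 log units; beyond the scatter) in this assay, and is estimated at 600 nM within a range from 100 nM to 5000 nM.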

Compound 4, half-maximal effective concentration: > 50000 nM
Compound 4 was reported as a limit; the forecaster's own chance of this, stated with the estimate: 15%; at least 83-fold (1.92 log units) between middle value and limit.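

Exchanging (2,2-dimethoxyethyl)amino for (4-fluorobenzyl)oxy on the carbonyl carbon, with the rest of compound 1 unchanged, produces in this assay an at least 330-fold higher number from compound 1 to compound 4 (2.52 log units; beyond the scatter). For the compounds shown here, this is the first step at this position that starts from compound 1, and it shows that this one exchange is enough for the large loss, without the further difference that compounds 2 and 3 carry. The value of compound 4 is a limit and not a number, so the true size of the step remains unknown: the limit of > 50000 nM in this assay, at which 2 of the 4 values shown sit.

The compounds shown leave open whether the loss goes with the ester oxygen in place of the amide nitrogen or with the entering 4-fluorobenzyl ring. On these data alone, a (4-fluorobenzyl)amino group or a 2,2-dimethoxyethyl ester on the same carbonyl carbon would separate the two, and how a carboxylic acid at this place would read also remains open.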